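Thiophen-3-yl in place of pyridin-2-yl in compound 4

A few compounds are considered here, and "the series" means these few. Any claim that something is new, unique, unknown or untested is made for them only; others in the source may bear on it.

Values so far in a functional assay on A-375 cells (Homo sapiens) for antiproliferative activity (a higher number here means a weaker inhibitor, a lower number a stronger inhibitor), are these:
Compound 1 `O=C(Nc1ccc(-c2cscn2)cc1)C1CCN(Cc2ccc(F)c(F)c2)C1` gives 10000 nM
Compound 2 `O=C(Nc1ccc(-c2cscn2)cc1)C1CCCN(Cc2cccc(C(F)(F)F)c2)C1` gives > 20000 nM (a limit of the assay)
Compound 3 `O=C(Nc1ccc(-c2ccccn2)cc1)C1CCCN(Cc2ccc(F)c(F)c2)C1` gives 9000 nM

On these numbers compound 3 at 9000 nM lies within the scatter of compound 1 at 10000 nM in this assay for this series. The entry for compound 2 is only a limit.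

Compound 4 `O=C(Nc1ccc(-c2ccsc2)cc1)C1CCCN(Cc2ccc(F)c(F)c2)C1` has thiophen-3-yl in place of pyridin-2-yl on an aromatic carbon, para to a large group (thiophen-3-yl in place of pyridin-2-yl on an aromatic carbon). No measured single change is available, so no step beyond the scatter is expected in this assay in either direction. The expected change a 1.1-fold lower number from compound 3 to compound 4 (0.05 log units; within the scatter) is therefore small. Compound 4 is estimated at 8000 nM with an expected range from 3500 nM to 20000 nM in this reading.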

Compound 4, half-maximal inhibitory concentration: 950 nM
Compound 4: middle estimate off by 8.4-fold (0.93 log units), on the high side; the measured number lies below the stated range.
By their numbers in this assay, from the lowest: compound 4; then compounds 3 and 1 (each within the scatter of the next). At a limit, above all of these: compound 2.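

In this assay, thiophen-3-yl in place of pyridin-2-yl gives a 9.5-fold lower number from compound 3 to compound 4 (0.98 log units; beyond the scatter). For the compounds shown here, this is the only single change measured, and it shows that the ring on this aromatic carbon, para to a large group, can move the number beyond the scatter. Nothing shown here accounts for the size of the step.

Going by these compounds, whether a phenyl or furan-3-yl ring on this carbon would give a similar number remains open. So does whether the step holds when the rest of compound 4 differs.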